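The source may hold more compounds than are shown below. What is called first, only, known or untested is meant among the compounds shown, and "the series" means these compounds.

The measured compounds so far:

Compound 1, `O=C(NC1CCN(Cc2ccc(Cl)cc2)CC1)c1cccc2ccccc12`: in an assay on isolated protein for displacement of a labelled ligand from D(4) dopamine receptor (Homo sapiens) (a lower number here means a stronger inhibitor, a higher number a weaker inhibitor), compound 1 gives 43 nM.
Compound 2, `O=C(NC1CCN(Cc2cccc(Br)c2)CC1)c1cccc2ccccc12`: compound 2 gives 66 nM.
Compound 3, `O=C(NC1CCN(Cc2ccc(Cl)cc2)CC1)c1ccc2ccccc2c1`: compound 3 gives 37 nM.

All three values lie within the usual scatter of one another, so none of them can be called stronger or weaker than the others. Compound 4, `O=C(NC1CCN(Cc2cccc(Br)c2)CC1)c1ccc2ccccc2c1`, has not yet been measured. It differs from compound 3 in one place: 3-bromophenyl in place of 4-chlorophenyl on a saturated chain carbon bound to an amine nitrogen in a ring. The same change is seen between two measured compounds, since compound 2 differs from compound 1 as 3-bromophenyl in place of 4-chlorophenyl on a saturated chain carbon bound to an amine nitrogen in a ring, and that change made a 1.5-fold higher number from compound 1 to compound 2 (0.19 log units; within the scatter). The place of the change is described in the same words for both pairs, so it is the same change on a different core; how the core of compound 1 and the core of compound 3 differ is not broken down here. Because a 1.5-fold higher number from compound 1 to compound 2 (0.19 log units; within the scatter) was small, a comparable small step is expected for compound 4, namely a 1.5-fold higher number from compound 3 to compound 4 (0.17 log units; within the scatter). Compound 4 is therefore estimated at 55 nM, expected to fall between 25 nM and 120 nM.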

Compound 4, inhibition constant: 36 nM
For compound 4 the middle estimate is 1.5-fold (0.18 log units) above the measured one; the range from low to high includes it.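

Putting 3-bromobenzyl in place of 4-chlorobenzyl gives a 1.0-fold lower number from compound 3 to compound 4 (0.01 log units; within the scatter) in this assay. Set beside the earlier step, the same change reads alike on the two cores: the same change on two cores in this assay, a 1.5-fold higher number (0.19 log units; within the scatter) from compound 1 to compound 2 and a 1.0-fold lower number (0.01 log units; within the scatter) from compound 3 to compound 4, 1.6-fold (0.20 log units) apart, within the scatter of two such steps. This shows that on these two cores the swap leaves the number within the scatter, but it does not show that the two groups are interchangeable on any third core, and a real difference smaller than the scatter would stay hidden.

The swap also changes the halogen and its position together, so the compounds shown leave open how 3-chlorophenyl or 4-bromophenyl would read in this assay, which would tell those two parts of the change apart. They also leave open whether a quite different group on the phenyl ring, such as an amine or a carboxylic acid, or a longer chain leading to the amine nitrogen in a ring, would shift the number beyond the scatter.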